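This account rests on a few compounds, and the source may have more. Where it says the series, first, only, none or still open, it means among the compounds named here.

Working notes on the series sharing the core of compound 1 `CS(=O)(=O)Cc1cccc2c1CCC2c1ncc[nH]1`. In a functional assay on CHO cells for agonist activity at Alpha-1A adrenergic receptor (Homo sapiens), read by fluorescence and calcium flux (a higher number here means a larger maximal response, a lower number a smaller maximal response), compound 1 gives 70%. Compound 2 `COCc1cccc2c1CC[C@H]2c1ncc[nH]1` in this assay gives 69%, the second highest of the three numbers; its nearest neighbour is compound 1, which lies within the scatter of it, and its furthest is compound 3 `COCCc1cccc2c1CCC2c1ncc[nH]1`, which in this assay gives 50%, a gap beyond the scatter. Going by the values given here, the single step between measured compounds that differ in one place runs a number 20 percentage points lower from compound 1 to compound 3 (beyond the scatter), with methoxymethyl in place of methylsulfonyl on a saturated chain carbon bound to an aromatic carbon.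

Compound 4 `COCc1c(F)ccc2c1CC[C@H]2c1ncc[nH]1` differs from compound 2 by fluoro in place of hydrogen on an aromatic carbon. Among the compounds with values here, no measured step in this assay concerns a change on the aromatic ring, so the step from compound 1 to compound 3 does not bear directly on this one; it only shows that changes at the chain position move the maximal response modestly. Without a comparable step the expectation for compound 4 is a step of a number 1 percentage points lower from compound 2 to compound 4 (within the scatter), that is, no movement beyond the scatter. Compound 4 is therefore estimated at 68%, with a range from 50% to 85%.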

Compound 4, largest response reached (Emax), in percent of the reference or control that the assay uses: 59%
Compound 4: middle estimate off by 9 percentage points, on the high side, within the range that was stated.
By their numbers in this assay, from the lowest: compounds 3, 4, 2 and 1 (each within the scatter of the next, the first and the last beyond it).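

Going by these compounds alone, this is the first measured change on the aromatic ring of the series. In this assay the step is a number 10 percentage points lower from compound 2 to compound 4 (within the scatter), with fluoro in place of hydrogen on an aromatic carbon ortho to a methoxymethyl group, meta to a fused ring and para to a fused ring. This position therefore takes fluoro with the maximal response staying within the scatter, a reading that rests on this single pair, with the methoxymethyl group and the stereocentre of compound 2 held in place. No measurement at hand offers an explanation for this step.

Whether chloro, methoxy or an amine at the same aromatic carbon would move the maximal response beyond the scatter remains open, as the fluoro compound is the only substituted example at this position among the compounds shown. Also open, as far as these compounds go, is whether fluoro here would give a comparable step alongside the methylsulfonyl group of compound 1 or the longer methoxy-bearing chain of compound 3, and whether fluoro on the other aromatic carbons would do the same.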